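Hydroxy to Carboxy: What the Two Measured Amides Suggest

The source may hold more compounds than are shown below. What is called first, only, known or untested is meant among the compounds shown, and "the series" means these compounds.

Compound 1 `COc1ccc2nc(C(=O)Nc3ccc(-c4ccccc4)cc3)c(C)c(O)c2c1` was tested in a functional assay on Hep 3B2 cells (Homo sapiens) for antiproliferative activity, read by MTT assay, with a stated time of 24 h, tested at 11.11 ug/mL (on this read-out lower numbers stand for a weaker effect and higher numbers for a stronger effect at the one concentration tested), where compound 1 gives 36.3%. Its closest relative, compound 2 `Cc1c(C(=O)Nc2ccc(-c3ccccc3)cc2)nc2ccccc2c1O`, gives 38.3% in this assay, and the change between them, hydrogen in place of methoxy on an aromatic carbon, moves the read-out by a number 2 percentage points higher from compound 1 to compound 2 (within the scatter). On the numbers shown, compound 1 and compound 2 therefore sit within the usual scatter of each other.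

Compound 3 `COc1ccc2nc(C(=O)Nc3ccc(-c4ccccc4)cc3)c(C)c(C(=O)O)c2c1` has not yet been measured. It differs from compound 1 as follows: carboxy in place of hydroxy on an aromatic carbon. Going by the values given here, no measured step touches the hydroxy group, so the single known step, which concerns the methoxy group, offers no direct guide to this change. The read-out for compound 3 in this assay is estimated at 36%, with a range from 15% to 55%, which means an expected step of a number 0.3 percentage points lower from compound 1 to compound 3 (within the scatter).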

Compound 3, a percentage reported as inhibition, at one concentration (the size of the read-out at that concentration, not a potency): 28.3%
Beside the measured number, compound 3's estimate is 7.7 percentage points above it, within the range that was stated.
By their numbers in this assay, from the lowest: compounds 3, 1 and 2 (each within the scatter of the next).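

Going by these compounds alone, this is the first measurement at the position opposite the ring nitrogen: in this assay, carboxy in place of hydroxy gives a number 8 percentage points lower from compound 1 to compound 3 (within the scatter), the only step at this position so far. A group of three heavy atoms can therefore stand where a single-atom hydroxy stood without a step beyond the scatter, so this one swap does not show that the hydroxy group is needed for the effect at the one concentration tested. Nothing available explains this result or says what either group does here.

From the compounds shown here alone, it remains open whether an amine or a methyl ester at this position would give a step beyond the scatter. Also open, going by these compounds, is whether carboxy would give a similar result on the core of compound 2, which lacks the methoxy group.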